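This account rests on a few compounds, and the source may have more. Where it says the series, first, only, none or still open, it means among the compounds named here.

Compound 1 `ClCc1ccccc1Cn1cnc2nc(Cl)nc(Cl)c21` carries two chloro groups on the shared core. In a functional assay on UO-31 cells (Homo sapiens) for cytotoxicity, read by sulforhodamine B assay, with a stated time of 48 h (a lower number here means a stronger inhibitor of growth, a higher number a weaker inhibitor of growth), compound 1 gives "not determined" (no result reported), so there is no number of its own to stand on. The nearest measured relative is compound 2 `ClCc1ccc(Cn2cnc3c(Cl)nc(Cl)nc32)cc1`, a close structural cousin of compound 1; in this assay compound 2 gives 35500 nM, a weak result on this scale.

Compound 3 `ClCc1ccccc1Cn1cnc2ncnc(Cl)c21` is reached from compound 1 by one change: hydrogen in place of chloro on an aromatic carbon, the hydrogen entering on an aromatic carbon of a six-membered aromatic ring with 2 nitrogen, between two ring nitrogen atoms. For the measured compounds named here, no measured step of this kind exists in the set, and compound 1 itself has no value, so the size of the step in this assay can only be guessed. Removal of one chloro group is expected to leave the total growth inhibition concentration near where compound 2 stands, if anything a little higher, with no confident direction beyond the scatter. For compound 3 the concentration in this assay is estimated at 45000 nM, with a range from 12000 nM to 150000 nM.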

Compound 3, concentration for total growth inhibition: 10700 nM
For compound 3 the middle estimate is 4.2-fold (0.62 log units) above the measured one; the measured number lies below the stated range.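

No step can be read between compound 1 and compound 3, as compound 1 has no single number in this assay. The compounds shown leave open what replacing the chloro group between two ring nitrogen atoms with hydrogen does to growth inhibition. No supporting data bear on this result.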